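Bromo for chloro on a benzylic aryl ring

The compounds below may be only part of what the source reports. "The series", "measured", "known", "first", "only" and "open" are said of these compounds alone.

Of the compounds shown here, three sharing one core have been measured in a functional assay on T29Kt1 cells (Homo sapiens) for cytotoxicity, read by sulforhodamine B assay, with a stated time of 3 days; a lower number here means a stronger inhibitor, a higher number a weaker inhibitor. Compound 1 `OCc1cn(Cc2cccc(Cl)c2)c2ccccc12` gives 160 nM. Compound 2 `OCc1cn(Cc2ccc(Cl)cc2)c2ccccc12` gives 79 nM. Compound 3 `OCc1cn(Cc2cccc(Br)c2)c2ccccc12` gives 32 nM. Compounds 1 and 2 have the same atoms joined differently; the difference between the two cores is not broken down here, and their values show compound 2 with the lower number.

One change is made twice among these compounds. From compound 1 to compound 3 it is bromo in place of chloro on an aromatic carbon, and it made a 5.0-fold lower number from compound 1 to compound 3 (0.70 log units; beyond the scatter). From compound 2 to compound 4 `OCc1cn(Cc2ccc(Br)cc2)c2ccccc12` it is bromo in place of chloro on an aromatic carbon. The two changes are the same kind of change but not the same: in the first the place is meta to a large group, in the second it is para to a large group.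

Compound 4 has not yet been measured in this assay. The step from compound 2 to compound 4 is expected to be a 3.2-fold lower number from compound 2 to compound 4 (0.50 log units; beyond the scatter), resting on the step from compound 1 to compound 3 of a 5.0-fold lower number from compound 1 to compound 3 (0.70 log units; beyond the scatter), with some allowance for the different place in the second pair. For compound 4 the estimate in this assay is 25 nM, expected to lie between 10 nM and 60 nM.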

Compound 4, half-maximal inhibitory concentration: 390 nM
Compound 4: the middle estimate sits 16-fold (1.19 log units) below what was measured, and the stated range ends below it.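

In this assay, putting bromo in place of chloro para to a large group gave a 4.9-fold higher number from compound 2 to compound 4 (0.69 log units; beyond the scatter). Set beside the same exchange at the other place on the ring, the direction reverses, and the two steps differ by more than repeat measurements would explain: the same change on two cores in this assay, a 5.0-fold lower number (0.70 log units; beyond the scatter) from compound 1 to compound 3 and a 4.9-fold higher number (0.69 log units; beyond the scatter) from compound 2 to compound 4, 25-fold (1.39 log units) apart, beyond the scatter of two such steps. This shows that, among these four compounds, the effect of bromo for chloro does not carry from one pair to the other, so the result from one place cannot be used to predict the result at the other; it does not show why the two steps part, and with a single pair at each place it does not show that either direction would hold for any other pair in the series.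

The compounds shown leave open how other groups would behave at these two places, such as fluoro, methoxy or a nitrile, and whether they too would give opposite steps. They also leave open whether the same reversal would survive if the hydroxymethyl group of the shared core gave way to an amine, a carboxylic acid or a longer chain.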